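Halogenated phenyl in place of methoxyphenyl on the shared core

This account rests on a few compounds, and the source may have more. Where it says the series, first, only, none or still open, it means among the compounds named here.

Measured compounds:
compound 1, `CCCNC(=O)c1cc(Oc2ccc(NC(=O)c3cc4cccnc4n(-c4ccccc4)c3=O)cc2)ccn1`, 95 nM
compound 2, `CCCNC(=O)c1cc(Oc2ccc(NC(=O)c3cc4cccnc4n(-c4ccc(Cl)cc4)c3=O)cc2)ccn1`, 120 nM
compound 3, `CCCNC(=O)c1cc(Oc2ccc(NC(=O)c3cc4cccnc4n(-c4ccc(OC)cc4)c3=O)cc2)ccn1`, 820 nM

In a functional assay on A549 cells (Homo sapiens) for antiproliferative activity, read by MTT assay, with a stated time of 72 h (on this read-out lower numbers stand for stronger inhibition and higher numbers for weaker inhibition), compound 3 gives the highest of the three numbers. The step of an 8.6-fold higher number from compound 1 to compound 3 (0.94 log units; beyond the scatter) and the step of a 6.8-fold higher number from compound 2 to compound 3 (0.83 log units; beyond the scatter) both place it well apart from the other two, while the step of a 1.3-fold higher number from compound 1 to compound 2 (0.10 log units; within the scatter) shows that compound 1 and compound 2 sit together.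

Compound 4, `CCCNC(=O)c1cc(Oc2ccc(NC(=O)c3cc4cccnc4n(-c4ccc(Br)cc4F)c3=O)cc2)ccn1`, carries 4-bromo-2-fluorophenyl in place of 4-methoxyphenyl on an aromatic nitrogen. The change removes the methoxy group that marks compound 3 and puts two halogens on the ring instead. For the measured compounds named here, the steps that bear on it are those from compound 1 and compound 2 to compound 3, which show that the methoxy group goes with a higher number, and the step from compound 1 to compound 2, which shows that a single chloro leaves the number where it is. Compound 4 is therefore expected to move back toward the numbers of compound 1 and compound 2, giving a step of a 5.5-fold lower number from compound 3 to compound 4 (0.74 log units; beyond the scatter) in this assay. Going by the values given here, the added fluoro has no measured counterpart here, so the range is kept wide. Compound 4 is estimated at 150 nM, between 55 nM and 450 nM.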

Compound 4, half-maximal inhibitory concentration: 1310 nM
Compound 4: middle estimate off by 8.7-fold (0.94 log units), on the low side; the whole stated range lies below it.
By their numbers in this assay, from the lowest: compounds 1 and 2 (each within the scatter of the next); then compounds 3 and 4 (each within the scatter of the next).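

On the aromatic nitrogen of the shared core, 4-bromo-2-fluorophenyl sits with 4-methoxyphenyl in this assay (a 1.6-fold higher number from compound 3 to compound 4 (0.20 log units; within the scatter)), and not with phenyl (a 14-fold higher number from compound 1 to compound 4 (1.14 log units; beyond the scatter)) or 4-chlorophenyl (an 11-fold higher number from compound 2 to compound 4 (1.04 log units; beyond the scatter)). Taking away the methoxy group is therefore not enough to return to the lower numbers, and halogen on this ring does not by itself leave the number unchanged: 4-chlorophenyl stays with phenyl, whereas 4-bromo-2-fluorophenyl does not. Two groups with different atoms thus share one level here, and nothing available explains why the ring of compound 4 parts from that of compound 2.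

The bromo and the fluoro of 4-bromo-2-fluorophenyl arrive together, so the compounds shown cannot say which of the two, or whether only the pair, goes with the higher number. Also open, on these data alone, is how this position answers to a phenyl ring carrying an amine or a carboxylic acid, or to a longer chain in place of the ring.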